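Swapping the Aromatic Group on Compound 2

The source may hold more compounds than are shown below. What is called first, only, known or untested is meant among the compounds shown, and "the series" means these compounds.

Measured in a functional assay (muscle tissue) with Cavia porcellus as the target; a higher number here means that more compound is needed for the effect, a lower number that less compound is needed:
Compound 1 `COC(=O)C1=C(C)N=C(C)/C(=C(\O)OC)C1c1ccccc1C#N`: 15.9 nM
Compound 2 `COC(=O)C1=C(C)N=C(C)/C(=C(\O)OC)C1c1ccccc1C`: 6.03 nM

Compound 2 stands lowest of the two at 6.03 nM, so less of it is needed for the effect. Compound 3 `COC(=O)C1=C(C)N=C(C)/C(=C(\O)OC)C1c1ccc(Cl)cc1Cl` keeps the shared core but replaces a whole group: 2,4-dichlorophenyl in place of 2-methylphenyl on a saturated ring carbon. It carries 2,4-dichlorophenyl in place of 2-methylphenyl on a saturated ring carbon, next to the ring atom that bears a methoxycarbonyl group.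

Among the compounds with values here, only one measured step bears on this, a 2.6-fold lower number from compound 1 to compound 2 (0.42 log units; beyond the scatter), where methyl took the place of cyano on an aromatic carbon. That step was modest and involved no chlorine, so it offers only a rough guide to size and none to direction. A modest move towards a higher number in this assay is a cautious expectation. The expected step is a 2.0-fold higher number from compound 2 to compound 3 (0.30 log units; within the scatter). The estimate for compound 3 is 12 nM, with an expected range from 4 nM to 36 nM.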

Compound 3, half-maximal effective concentration: 640 nM
For compound 3 the middle estimate is 53-fold (1.73 log units) below the measured one, outside the stated range (above it).
By their numbers in this assay, from the lowest: compound 2; then compound 1; then compound 3.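

In this assay, this position turns out to be far more sensitive than the first two compounds suggested. Putting 2,4-dichlorophenyl in place of 2-methylphenyl brings a 110-fold higher number from compound 2 to compound 3 (2.03 log units; beyond the scatter), and putting it in place of 2-cyanophenyl brings a 40-fold higher number from compound 1 to compound 3 (1.60 log units; beyond the scatter), so much more compound is needed for the effect and both steps are large beside the modest one between the earlier pair. Nothing measured here accounts for the size of this jump.

Going by these compounds, whether one of the two chlorines alone produces this rise, or only both together do, stays open. Also open, on these data alone, is how the number would respond to a methoxy group or an amine on the phenyl ring.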